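This account rests on a few compounds, and the source may have more. Where it says the series, first, only, none or still open, it means among the compounds named here.

Measured in a functional assay on KB 3-1 cells (Homo sapiens), with a stated time of 1 h; a higher number here means that more compound is needed for the effect, a lower number that less compound is needed:

compound 1 `CC(=O)Oc1cc2oc(-c3ccccc3)cc(=O)c2c(O)c1OC(C)=O` gives 9700 nM;
compound 2 `CC(=O)Oc1cc2oc(-c3ccccc3)cc(=O)c2c(OC(C)=O)c1OC(C)=O` gives 6800 nM;
compound 3 `CC(=O)Oc1cc2oc(-c3ccccc3)cc(=O)c2c(OCc2ccccc2)c1OC(C)=O` gives 3700 nM.

Compound 1 carries the highest number of the three, shown by a 1.4-fold lower number from compound 1 to compound 2 (0.15 log units; within the scatter) and by a 2.6-fold lower number from compound 1 to compound 3 (0.42 log units; beyond the scatter). Compound 4 `CC(=O)Oc1c(OC(C)=O)c(O)c2c(=O)cc(-c3ccccc3)oc2c1Br` differs from compound 1 by bromo in place of hydrogen on an aromatic carbon. Within the data shown here, none of the measured steps touches an aromatic carbon: a 1.4-fold lower number from compound 1 to compound 2 (0.15 log units; within the scatter), a 2.6-fold lower number from compound 1 to compound 3 (0.42 log units; beyond the scatter) and a 1.8-fold lower number from compound 2 to compound 3 (0.26 log units; within the scatter) all concern substituents on an oxygen, so they carry no direct weight for this change. With nothing closer to lean on, the step of a 1.3-fold lower number from compound 1 to compound 4 (0.11 log units; within the scatter) is expected to stay small, at most modest, and its direction is uncertain. Compound 4 is therefore estimated in this assay at 7500 nM, in a range from 2500 nM to 22000 nM.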

Compound 4, half-maximal effective concentration: 15000 nM
Beside the measured number, compound 4's estimate is 2.0-fold (0.30 log units) below it, and the stated range covers the measured number.
By their numbers in this assay, from the lowest: compounds 3, 2, 1 and 4 (each within the scatter of the next, the first and the last beyond it).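

Among these compounds, compound 4 is the first change on an aromatic carbon rather than on an oxygen. In this assay, bromo on this carbon, para to a hydroxy group, gives a 1.5-fold higher number from compound 1 to compound 4 (0.19 log units; within the scatter), so this single bromine stays within the scatter and the hydroxy group is kept. On these data alone, whether an amine, a methoxy group or a carboxylic acid on this aromatic carbon would move the number beyond the scatter remains open, as does the outcome of bromo combined with the benzyl group of compound 3. Nothing available bears on the cause of this result.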